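Swapping the Aryl Group at the Ring Carbon

This account rests on a few compounds, and the source may have more. Where it says the series, first, only, none or still open, it means among the compounds named here.

Compound 1 `COc1ccc(C2CC(c3ccccc3)=NN2C2=NC(=O)/C(=C3\C(=O)Nc4ccccc43)S2)cc1`: in a functional assay on cells (Cancer cell lines, Homo sapiens) for cytotoxicity, read by sulforhodamine B assay, with a stated time of 48 h (on this read-out higher numbers stand for weaker inhibition of growth and lower numbers for stronger inhibition of growth), compound 1 gives 3450 nM.
Compound 2 `COc1ccc(C2=NN(C3=NC(=O)/C(=C4\C(=O)Nc5ccccc54)S3)C(c3ccc(OC)cc3)C2)cc1`: in this assay compound 2 gives 89200 nM.

Among the measured compounds shown here, compound 2 stands at the highest of the two numbers, and its only neighbour is compound 1; the single measured step, a 26-fold higher number from compound 1 to compound 2 (1.41 log units; beyond the scatter), shows that adding a methoxy to the aryl ring on the carbon with a double bond to nitrogen goes with far weaker growth inhibition.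

Compound 3 `COc1ccc(C2CC(c3ccc4ccccc4c3)=NN2C2=NC(=O)/C(=C3\C(=O)Nc4ccccc43)S2)cc1` differs from compound 2 by naphthalen-2-yl in place of 4-methoxyphenyl on a carbon with a double bond to nitrogen. The methoxy that came with the large loss is gone again. For the measured compounds named here, the step of a 26-fold higher number from compound 1 to compound 2 (1.41 log units; beyond the scatter) bears on this change; the second ring, however, has no measured counterpart here. A large step toward stronger inhibition is therefore expected, an 11-fold lower number from compound 2 to compound 3 (1.05 log units; beyond the scatter), with added uncertainty from the untested ring. Compound 3 is estimated at 8000 nM, in a range from 2000 nM to 40000 nM.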

Compound 3, concentration for total growth inhibition: 12600 nM
Beside the measured number, compound 3's estimate is 1.6-fold (0.20 log units) below it; the range from low to high includes it.
By their numbers in this assay, from the lowest: compound 1; then compound 3; then compound 2.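

In this assay the swap of 4-methoxyphenyl for naphthalen-2-yl gives a 7.1-fold lower number from compound 2 to compound 3 (0.85 log units; beyond the scatter) and so wins back part of the ground lost with the methoxy, yet the same group set against the plain phenyl of compound 1 gives a 3.7-fold higher number from compound 1 to compound 3 (0.56 log units; beyond the scatter) and does not win back all of it. This carbon therefore accepts a second fused aromatic ring with only a modest cost, and among these three groups phenyl gives the strongest growth inhibition and 4-methoxyphenyl the weakest. Group size alone does not set this order, since naphthalen-2-yl has more heavy atoms than 4-methoxyphenyl and still gives the lower number. No measurement here explains these differences. Still open, from the compounds shown here alone, is how a hydroxyl or an amine would read in place of the methoxy on this aryl ring, and how a pyridine ring would compare with phenyl at this carbon.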